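Next group on the carbonyl carbon: compound 3

The compounds below may be only part of what the source reports. "The series", "measured", "known", "first", "only" and "open" are said of these compounds alone.

In an ADME assay on microsomes from liver (Mus musculus) for metabolic stability, read by LC-MS, with a stated time of 30 min, tested at 1 uM (a lower number here means that less of the compound is left, a higher number that more of the compound is left), compound 2 (`O=C(NCc1ccc(S(=O)(=O)c2ccccc2)cc1)c1cc2cnccc2[nH]1`) gives 54% and stands above compound 1 (`O=C(NCc1ccc(S(=O)(=O)c2ccccc2)cc1)c1nc2ccncc2s1`) which gives 26% on this measure. Compound 3 (`O=C(NCc1ccc(S(=O)(=O)c2ccccc2)cc1)c1cnc2nccn2c1`) differs from compound 2 by a group of 9 heavy atoms (6 carbon, 3 nitrogen; one five-membered aromatic ring with 2 hetero atoms, one six-membered aromatic ring with 2 hetero atoms) in place of a group of 9 heavy atoms (7 carbon, 2 nitrogen; one five-membered aromatic ring with 1 hetero atom, one six-membered aromatic ring with 1 hetero atom), on a carbonyl carbon and is otherwise unchanged. Among the compounds with values here, the only measured guide is a number 28 percentage points higher from compound 1 to compound 2 (beyond the scatter) so a swap at this place can move the number, but no direction follows for the new group. The expected change is a number 7 percentage points lower from compound 2 to compound 3 (within the scatter) in this assay and so none beyond the scatter is predicted. Compound 3 is estimated at 47% with an expected range from 22% to 72% for now.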

Compound 3, percent of the compound remaining: 30%
Beside the measured number, compound 3's estimate is 17 percentage points above it, within the range that was stated.
By their numbers in this assay, from the lowest: compounds 1 and 3 (each within the scatter of the next); then compound 2.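

In this assay, the swap on a carbonyl carbon gives a number 24 percentage points lower from compound 2 to compound 3 (beyond the scatter) and so, unlike the first step, shows that the number can also fall at this place. The other new comparison is a number 4 percentage points higher from compound 1 to compound 3 (within the scatter) and leaves compound 2 as the only one of the three set apart by the scatter. Nothing measured here gives a reason for these differences.

On these data alone, whether the loss of the hydrogen-bond donor matters remains open, as the entering group also differs in its rings and hetero atoms. As far as these compounds go, how a single-ring pyridine or a phenyl would behave at this place also remains open.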